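The source may hold more compounds than are shown below. What is called first, only, known or untested is meant among the compounds shown, and "the series" means these compounds.

Compound 2, `Cc1ccc(S(=O)(=O)N(Cc2nnc(Cc3ccc(N(C)C)cc3)o2)c2cccc(Cl)c2C)cc1`, is the starting point of this step. For the measured compounds named here, in an assay on CHO cells for displacement of a labelled ligand from prostaglandin E2 receptor EP1 subtype (Homo sapiens) (a higher number here means a weaker inhibitor, a lower number a stronger inhibitor), compound 2 gives 12.6 nM, the higher of the two numbers measured so far. Going by the values given here, the only neighbour is compound 1, `COc1ccc(Cc2nnc(CN(c3cccc(Cl)c3C)S(=O)(=O)c3ccc(C)cc3)o2)cc1`, which in this assay gives 6.31 nM; the step of a 2.0-fold higher number from compound 1 to compound 2 (0.30 log units; within the scatter) is the one change recorded at this position of the molecule, and it stayed within the scatter.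

Compound 3, `Cc1ccc(S(=O)(=O)N(Cc2nnc(Cc3ccc(C(F)(F)F)cc3)o2)c2cccc(Cl)c2C)cc1`, has not yet been measured. It differs from compound 2 in one place: trifluoromethyl in place of dimethylamino on an aromatic carbon. The shared core, the sulfonyl-bearing nitrogen and the rest of the molecule are unchanged.

Among the compounds with values here, the single measured step that bears on this exchange is a 2.0-fold higher number from compound 1 to compound 2 (0.30 log units; within the scatter), which swapped one group for another at the same aromatic carbon without moving the number beyond the scatter. On that basis, and with no other information about this position, a step of modest size is expected for compound 3, most likely again within the scatter, in either direction.

Compound 3 is therefore expected to give about 14 nM in this assay, with a plausible range from 4 nM to 50 nM, which would correspond to a step of a 1.1-fold higher number from compound 2 to compound 3 (0.05 log units; within the scatter).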

Compound 3, half-maximal inhibitory concentration: 50.1 nM
The estimate for compound 3 lay 3.6-fold (0.55 log units) below the measured number, and the stated range ends below it.
By their numbers in this assay, from the lowest: compounds 1 and 2 (each within the scatter of the next); then compound 3.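

In this assay, the group on this aromatic carbon turns out to matter: trifluoromethyl in place of dimethylamino gives a 4.0-fold higher number from compound 2 to compound 3 (0.60 log units; beyond the scatter) and trifluoromethyl in place of methoxy gives a 7.9-fold higher number from compound 1 to compound 3 (0.90 log units; beyond the scatter), and both steps lie beyond the scatter. The earlier pair could not show this, since methoxy and dimethylamino stayed within the scatter of each other and so cannot be ranked. Trifluoromethyl is now the one group of the three that stands apart, giving the weakest inhibitor of the set, although both steps are only modest in size, and nothing measured here explains the difference.

For the compounds shown here, with only three groups seen on this carbon, it remains open whether a plain hydrogen, a chlorine atom, a primary amine or a carboxylic acid would fall with methoxy and dimethylamino or with trifluoromethyl. On these data alone, it is also open whether the same order would hold with these groups on another carbon of the ring, or with a longer chain in place of the benzyl link.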